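The source may report more compounds than this note shows. Statements on the series, on what has been measured and on what is new or still open speak of the compounds shown alone.

Compound 1 `O=C(NCc1cc(C(F)(F)F)cc(C(F)(F)F)c1)c1c(CBr)nc2ccccc2c1-c1ccccc1`: 0.01 nM
Compound 2 `CN(Cc1cc(C(F)(F)F)cc(C(F)(F)F)c1)C(=O)c1c(CO)nc2ccccc2c1-c1ccccc1`: 16 nM

In an in vitro assay on UC11MG cells for binding affinity to Substance-P receptor (Homo sapiens), read by radioligand binding (on this read-out lower numbers stand for stronger inhibition and higher numbers for weaker inhibition), compound 1 gives 0.01 nM, the lower of the two numbers. Compound 2 gives 16 nM, far higher and beyond the scatter. Compound 3 `O=C(NCc1cc(C(F)(F)F)cc(C(F)(F)F)c1)c1c(CN2C(=O)c3ccccc3C2=O)nc2ccccc2c1-c1ccccc1` differs from compound 1 by a group of 11 heavy atoms (8 carbon, 1 nitrogen, 2 oxygen; one five-membered non-aromatic ring with 1 hetero atom, one six-membered aromatic ring of carbon only) in place of one bromine atom, on a saturated chain carbon bound to an aromatic carbon. For the measured compounds named here, no step of this kind has been measured here, so the direction rests on the size of the change alone. He expects a weakening, with a 30-fold higher number from compound 1 to compound 3 (1.48 log units; beyond the scatter) as the estimated step. For compound 3 he estimates 0.3 nM, in the range 0.03 nM to 3 nM.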

Compound 3, half-maximal inhibitory concentration: > 1000 nM
Compound 3 was reported as a limit; the forecaster's own chance of this, stated with the estimate: 5%; middle value at least 3300-fold (3.52 log units) away from the limit.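

At the saturated chain carbon bound to an aromatic carbon, replacing bromo with the group of 11 heavy atoms gives, in this assay, an at least 100000-fold higher number from compound 1 to compound 3 (5.00 log units; beyond the scatter). For the compounds shown here, this position therefore does not accept every group: the one in compound 3 costs nearly all of the affinity seen with compound 1. The reading for compound 3 is a limit and not a number: the limit of > 1000 nM in this assay, at which 1 of the 3 values shown sits.

From the compounds shown here alone, whether a smaller group, such as a primary amine or a methoxy group, would keep the value of compound 1 stays open. So does whether the two-ring group loses affinity through its ring system or through its two carbonyl oxygens.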